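The source may report more compounds than this note shows. Statements on the series, on what has been measured and on what is new or still open speak of the compounds shown alone.

Measured so far in a functional assay on HCT-116 cells (Homo sapiens) for cytotoxicity, read by MTT assay, with a stated time of 72 h; a lower number here means a stronger inhibitor, a higher number a weaker inhibitor:
Compound 1 `Cc1ccc(-c2cc(/N=C3/NC(=O)CS3)cs2)cc1` gives > 50000 nM, a limit of the assay.
Compound 2 `O=C1CS/C(=N\c2csc(-c3ccccc3)c2)N1` gives > 50000 nM, also a limit of the assay.
Compound 3 `COc1ccc(/C=C2\S/C(=N\c3csc(-c4ccc(Cl)cc4)c3)NC2=O)cc1` gives 1300 nM.

Among the compounds with values here, compound 3 therefore stands alone as the only finite number in this assay; the other two entries are limits, and the limit of > 50000 nM in this assay, at which 2 of the 3 values shown sit, marks where they sit. Within the data shown here, the one step between measured compounds, a step that the two limits leave unreadable from compound 1 to compound 2, replaces a methyl on an aromatic carbon with hydrogen and cannot be read, because both ends are limits.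

Compound 4 `CN(C)c1ccc(/C=C2\S/C(=N\c3csc(-c4ccc(Cl)cc4)c3)NC2=O)cc1` differs from compound 3 by dimethylamino in place of methoxy on an aromatic carbon of a six-membered aromatic ring of carbon only, para to a large group, so that a 4-methoxyphenyl becomes a 4-(dimethylamino)phenyl.

Among the measured compounds shown here, no measured step touches this change. The only step shown, from compound 1 to compound 2, concerns a different group on a different ring and is unreadable in size. With nothing to lean on beyond the value of compound 3, the expectation for this assay is no step beyond the usual scatter: the expected step of no change at the digits printed from compound 3 to compound 4 (within the scatter) is flat. Compound 4 is therefore estimated at 1300 nM, with a range from 450 nM to 3800 nM.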

Compound 4, half-maximal inhibitory concentration: 500 nM
Compound 4: middle estimate off by 2.6-fold (0.41 log units), on the high side; measured number inside the range.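

Within the data shown here, the replacement of methoxy by dimethylamino, on an aromatic carbon of a six-membered aromatic ring of carbon only, para to a large group, is the first change whose size can be read in this assay: it gives a 2.6-fold lower number from compound 3 to compound 4 (0.41 log units; beyond the scatter) and so shows that the number responds to the group held at this place. Among these compounds, the only earlier step concerned hydrogen in place of methyl on a different ring and cannot be read, since both of its ends are limits, so the series offered no readable sign of how any single group counts until this pair. The data shown give no reason why dimethylamino gives the lower number here.

As far as these compounds go, whether a primary amine, a morpholine or a diethylamino group at the same place would move the number further, or back towards that of compound 3, remains open. From the compounds shown here alone, it is also open whether the same exchange of methoxy for dimethylamino gives a step of similar size when the rest of the core of compound 3 carries other groups.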